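The compounds below may be only part of what the source reports. "The series", "measured", "known", "first", "only" and "open" are said of these compounds alone.

Working notes on the series. The set in a functional assay on SGC-7901 cells (Homo sapiens) for antiproliferative activity, read by MTT assay, with a stated time of 48 h (a lower number here means a stronger inhibitor, a higher number a weaker inhibitor), holds three measured compounds: compound 1 `COc1ccc(/C=C/C(=O)/C=C/c2ccc(Oc3cc(=O)oc4ccccc34)cc2)cc1OC` gives 49400 nM, compound 2 `COc1cc(OC)c2c(=O)c(OCCCOc3ccccc3/C=C/C(=O)/C=C/c3ccccn3)c(-c3cc(OC)c(OC)c(OC)c3)oc2c1` gives 1080 nM, and compound 3 `COc1cc(OC)c2c(=O)c(OCCCOc3ccccc3/C=C/C(=O)/C=C/c3cccc([N+](=O)[O-])c3)c(-c3cc(OC)c(OC)c(OC)c3)oc2c1` gives 5400 nM, the second highest number of the three. Going by the values given here, the one single-point step measured so far, a 5.0-fold higher number from compound 2 to compound 3 (0.70 log units; beyond the scatter), is the only one that bears on the next change. Compound 4 `COc1cc(OC)c2c(=O)c(OCCCOc3ccccc3/C=C/C(=O)/C=C/c3scnc3C)c(-c3cc(OC)c(OC)c(OC)c3)oc2c1` differs from compound 3 by 4-methyl-1,3-thiazol-5-yl in place of 3-nitrophenyl on a double-bonded chain carbon bound to a double-bonded chain carbon. Both this step and the earlier one swap an aryl group for a heteroaryl group on the chain carbon, so a downward shift is expected in this assay, likely smaller than the measured step because the earlier step of a 5.0-fold higher number from compound 2 to compound 3 (0.70 log units; beyond the scatter) involved a different ring. Compound 4 is expected at 3000 nM, range 1000 nM to 9000 nM, corresponding to an estimated step of a 1.8-fold lower number from compound 3 to compound 4 (0.26 log units; within the scatter).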

Compound 4, half-maximal inhibitory concentration: 4780 nM
For compound 4 the middle estimate is 1.6-fold (0.20 log units) below the measured one, and the stated range covers the measured number.
By their numbers in this assay, from the lowest: compound 2; then compounds 4 and 3 (each within the scatter of the next); then compound 1.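

On a double-bonded chain carbon bound to a double-bonded chain carbon, 4-methyl-1,3-thiazol-5-yl and 3-nitrophenyl read alike in this assay (a 1.1-fold lower number from compound 3 to compound 4 (0.05 log units; within the scatter)), even though the two differ in ring size and heavy-atom count. Pyridin-2-yl now stands apart from both groups, with the second gap at (a 4.4-fold higher number from compound 2 to compound 4 (0.65 log units; beyond the scatter)). No supporting measurement accounts for this separation.

From the compounds shown here alone, how an unsubstituted phenyl or a pyridin-3-yl would read at this place remains open. So does whether the separation of pyridin-2-yl extends to other nitrogen-containing six-membered aromatic rings.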